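Back from the Naphthyl Ketone to a Phenyl-Type Ketone

The source may report more compounds than this note shows. Statements on the series, on what has been measured and on what is new or still open speak of the compounds shown alone.

Compound 3 `COc1cc(-c2nnc3n2NC(c2ccco2)C(C(=O)c2cccc4ccccc24)S3)cc(OC)c1OC` stands at the top of the three values shown: in a functional assay on A549 cells (Homo sapiens) for cytotoxicity, read by MTT assay, with a stated time of 48 h (a higher number here means a weaker inhibitor, a lower number a stronger inhibitor), compound 3 gives > 100000 nM, which is a limit of the assay rather than a number (the limit of > 100000 nM in this assay, at which 1 of the 3 values shown sits). Compound 1 `COc1cc(-c2nnc3n2NC(c2ccco2)C(C(=O)c2cccs2)S3)cc(OC)c1OC` gives 78700 nM in this assay. Compound 2 `COc1cc(-c2nnc3n2NC(c2ccco2)C(C(=O)c2ccccc2)S3)cc(OC)c1OC` gives 33400 nM in this assay. The measured steps of an at least 1.2-fold higher number from compound 1 to compound 3 (0.10 log units; that floor lies within the scatter) and an at least 2.9-fold higher number from compound 2 to compound 3 (0.47 log units; beyond the scatter) point in one direction, though only the second is beyond the scatter.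

Compound 4 `COc1ccc(C(=O)C2Sc3nnc(-c4cc(OC)c(OC)c(OC)c4)n3NC2c2ccco2)cc1` differs from compound 3 by 4-methoxyphenyl in place of naphthalen-1-yl on a carbonyl carbon. Since 4-methoxyphenyl resembles phenyl, the reverse of an at least 2.9-fold higher number from compound 2 to compound 3 (0.47 log units; beyond the scatter) bears most directly, and a modest lowering of the number is expected. Compound 4 is therefore estimated at 40000 nM, with a range from 15000 nM to 110000 nM, an expected step of an at least 2.5-fold lower number from compound 3 to compound 4 (0.39 log units; beyond the scatter).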

Compound 4, half-maximal inhibitory concentration: > 100000 nM
Compound 4: only a limit was reported (the forecaster's own chance of this, stated with the estimate: 25%); middle value at least 2.5-fold (0.39 log units) from the limit.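

Compound 4 gives > 100000 nM in this assay, which is a limit of the assay and not a number: the limit of > 100000 nM in this assay, at which 2 of the 4 values shown sit.

Methoxy in place of hydrogen on an aromatic carbon of the phenyl ketone gives an at least 2.9-fold higher number from compound 2 to compound 4 (0.47 log units; beyond the scatter), so a phenyl-type ketone alone does not hold the lower number. Against the thiophen-2-yl ketone the change reads an at least 1.2-fold higher number from compound 1 to compound 4 (0.10 log units; that floor lies within the scatter), and the step between the two compounds at the limit cannot be read.

Still open, on these data alone, is whether a hydroxyl or an amine in place of the methoxy would bring the number back down.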